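This account rests on a few compounds, and the source may have more. Where it says the series, first, only, none or still open, it means among the compounds named here.

Measured so far:
- compound 1 `Nc1nc(NC2CCCCC2)sc1C(=O)c1ccccc1`: 9200 nM
- compound 2 `Nc1nc(Nc2ccccc2)sc1C(=O)c1cccnc1`: 5900 nM
- compound 3 `Nc1nc(Nc2ccccc2)sc1C(=O)c1ccc(F)cc1`: 16000 nM

In a functional assay on GC-1 cells (Mus musculus) for cytotoxicity, read by MTT assay, with a stated time of 72 h (on this read-out higher numbers stand for weaker inhibition and lower numbers for stronger inhibition), compound 3 gives 16000 nM. That value lies within the scatter of the value for compound 1, so the two cannot be told apart, but it is clearly separated from the value for compound 2.

Compound 4 `Nc1nc(Nc2ccccc2)sc1C(=O)c1cccc(F)c1` has not yet been measured. It carries 3-fluorophenyl in place of 4-fluorophenyl on a carbonyl carbon.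

Going by the values given here, only one measured step bears on this place, a 2.7-fold higher number from compound 2 to compound 3 (0.43 log units; beyond the scatter). It is modest, and it exchanged pyridin-3-yl for 4-fluorophenyl, a larger change than the one here. Among the compounds with values here, no measured pair shows what moving the fluorine does, so no step beyond the scatter is expected in this assay, and no direction can be firmly predicted.

The expected change is a 1.2-fold lower number from compound 3 to compound 4 (0.09 log units; within the scatter). For compound 4 the estimated value is 13000 nM, with an expected range of 6000 nM to 28000 nM.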

Compound 4, half-maximal inhibitory concentration: 3600 nM
Compound 4: the middle estimate sits 3.6-fold (0.56 log units) above what was measured; measured number below the stated range.
By their numbers in this assay, from the lowest: compounds 4, 2, 1 and 3 (each within the scatter of the next, the first and the last beyond it).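

In this assay the place of the fluorine matters: 3-fluorophenyl in place of 4-fluorophenyl on the carbonyl carbon gives a 4.4-fold lower number from compound 3 to compound 4 (0.65 log units; beyond the scatter) even though the two groups have the same atoms. Against pyridin-3-yl, the same 3-fluorophenyl group gives a 1.6-fold lower number from compound 2 to compound 4 (0.21 log units; within the scatter) and so cannot be told apart from it, whereas 4-fluorophenyl could be. Nothing available explains why moving the fluorine shifts the number.

The compounds shown leave open whether other groups on this phenyl ring, such as a chlorine or a methoxy group, would behave like the fluorine in compound 4 or like the one in compound 3. They also leave open whether the gap between the two fluorine placements would survive with the cyclohexyl group of compound 1 on the amino nitrogen.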